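One methyl comes off compound 2

A few compounds are considered here, and "the series" means these few. Any claim that something is new, unique, unknown or untested is made for them only; others in the source may bear on it.

When tested in a functional assay on PC-3 cells (Homo sapiens) for antiproliferative activity, read by MTT assay, with a stated time of 48 h (a higher number here means a weaker inhibitor, a lower number a stronger inhibitor), compound 1 (`COc1cc(O)ccc1N1CCN(CC(O)COc2cccc3ccccc23)CC1`) gives 24400 nM and compound 2 (`COc1cc(O)ccc1N1CCN(CC(O)COc2ccc(O)c3ccccc23)CC1`) gives 45700 nM on the same scale. These two numbers lie within the usual scatter of each other, so compound 2 cannot be told apart from compound 1.

Compound 3 (`Oc1ccc(N2CCN(CC(O)COc3ccc(O)c4ccccc34)CC2)c(O)c1`) is compound 2 with hydrogen in place of methyl on an oxygen on an aromatic ring, which turns methoxy to hydroxy (hydrogen in place of methyl on an oxygen on an aromatic ring). Going by the values given here, no measured step makes this exact change. Among the compounds with values here, the only guide is the move to compound 2, which put hydroxy in place of hydrogen on an aromatic carbon, a different kind of change at a different place. That move amounted to a 1.9-fold higher number from compound 1 to compound 2 (0.27 log units; within the scatter) as a measured step, so it offers no sign of a large shift.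

The estimated change is a 1.1-fold lower number from compound 2 to compound 3 (0.06 log units; within the scatter) and so no step beyond the scatter is expected in this assay for this swap. Compound 3 is expected at 40000 nM within an estimated range of 18000 nM to 90000 nM in this measurement.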

Compound 3, half-maximal inhibitory concentration: 17700 nM
Compound 3: middle estimate off by 2.3-fold (0.35 log units), on the high side, and the stated range ends above it.
By their numbers in this assay, from the lowest: compounds 3, 1 and 2 (each within the scatter of the next, the first and the last beyond it).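

In this assay, the swap of methoxy to hydroxy gives a 2.6-fold lower number from compound 2 to compound 3 (0.41 log units; beyond the scatter). Going by these compounds alone, this is the first step to pass beyond the scatter, since the earlier change on the other aromatic ring, a 1.9-fold higher number from compound 1 to compound 2 (0.27 log units; within the scatter), could not be told apart from repeat-measurement noise. The lower number marks compound 3 as a modestly stronger inhibitor than compound 2, so on this pair the methyl on that oxygen is not required for the antiproliferative effect, and removing it shifts the reading measurably, though nothing available explains why.

From the compounds shown here alone, this rests on a single pair, so it remains open whether the same swap would shift the number by a similar amount on compound 1, which carries hydrogen where compound 2 has its added hydroxy. Also open, going by these compounds, is how this assay would respond to an ethoxy group, with its longer chain on the same oxygen, or to an amine standing in place of the new hydroxy, and so whether the free hydroxy itself matters or only the loss of the methyl.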